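A Second Chlorine Added to a Shared Core

The compounds below may be only part of what the source reports. "The series", "measured", "known", "first", "only" and "open" are said of these compounds alone.

Compound 1 `ClCc1ccc(Cn2cnc3c(Cl)ncnc32)cc1` is tested in a functional assay on KM12 cells (Homo sapiens) for cytotoxicity, read by sulforhodamine B assay, with a stated time of 48 h (on this read-out lower numbers stand for stronger inhibition of growth and higher numbers for weaker inhibition of growth), where compound 1 gives 10200 nM. Compound 2 `ClCc1cccc(Cn2cnc3ncnc(Cl)c32)c1` is built from the same atoms joined differently; the difference between the two cores is not broken down here. In this assay compound 2 gives 3310 nM. Compound 3 `ClCc1ccc(Cn2cnc3c(Cl)nc(Cl)nc32)cc1` carries one change relative to compound 1, (chloro in place of hydrogen on an aromatic carbon). In this assay compound 3 gives 3240 nM, and that change made the step of a 3.1-fold lower number from compound 1 to compound 3 (0.50 log units; beyond the scatter). Compound 4 `ClCc1cccc(Cn2cnc3nc(Cl)nc(Cl)c32)c1` has not been measured. Among the measured compounds shown here, it differs from compound 2 by chloro in place of hydrogen on an aromatic carbon, the same change as the one seen between compound 1 and compound 3. Because of a 3.1-fold lower number from compound 1 to compound 3 (0.50 log units; beyond the scatter), the step to compound 4 is expected to be a 2.5-fold lower number from compound 2 to compound 4 (0.41 log units; beyond the scatter). Compound 4 is therefore estimated at 1300 nM, most likely between 500 nM and 3500 nM.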

Compound 4, concentration for total growth inhibition: 35500 nM
Compound 4: the middle estimate sits 27-fold (1.44 log units) below what was measured, outside the stated range (above it).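

Chloro in place of hydrogen on an aromatic carbon, here between two ring nitrogen atoms, gave an 11-fold higher number from compound 2 to compound 4 (1.03 log units; beyond the scatter) in this assay. This pair and the earlier one cannot explain why the two cores respond differently, and two cores set no rule for any others. Within these compounds, the step seen on one core did not carry over to the other, in direction or in size: the same change on two cores in this assay, a 3.1-fold lower number (0.50 log units; beyond the scatter) from compound 1 to compound 3 and an 11-fold higher number (1.03 log units; beyond the scatter) from compound 2 to compound 4, 34-fold (1.53 log units) apart, beyond the scatter of two such steps

The compounds shown leave open whether another group on that same carbon, such as an amine or a methoxy group, would also act differently on the two cores. They also leave open whether the cores would still differ with a hydroxymethyl group in place of the chloromethyl group.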